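Cyclobutyl to Phenyl on the Side Chain of Compound 2

The compounds below may be only part of what the source reports. "The series", "measured", "known", "first", "only" and "open" are said of these compounds alone.

This account concerns cytotoxicity toward human liver-derived cells, read as an ADME assay on Huh-7 cells (Homo sapiens) for cytotoxicity, with a stated time of 72 h; on this read-out higher numbers stand for lower toxicity in this test and lower numbers for higher toxicity in this test. Compound 1 `CC(C)=Cc1nn(CCC(C)C)c(=O)c(C2=NS(=O)(=O)c3cc(NS(C)(=O)=O)ccc3N2)c1O` gives > 1000 nM there, a limit of the assay rather than a number. Compound 2 `CS(=O)(=O)Nc1ccc2c(c1)S(=O)(=O)N=C(c1c(O)c(-c3cccs3)nn(CC3CCC3)c1=O)N2` likewise reaches only > 1000 nM in this assay, again a limit of the assay and not a number. Compound 2 thus stands where every value shown so far sits, namely at the limit of > 1000 nM in this assay, at which 2 of the 2 values shown sit. Within the data shown here, no step between measured compounds can be given; both values shown are limits, so no difference between them can be read.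

Compound 3 `CS(=O)(=O)Nc1ccc2c(c1)S(=O)(=O)N=C(c1c(O)c(-c3cccs3)nn(Cc3ccccc3)c1=O)N2` differs from compound 2 by phenyl in place of cyclobutyl on a saturated chain carbon bound to an aromatic nitrogen. With only limits to go on, the step from compound 2 to compound 3 in this assay is expected to be small, none beyond the scatter, and in no clear direction. Compound 3 is therefore estimated to give 3000 nM in this assay, within 1000 nM to 20000 nM. The expected step is a step that the limit leaves unreadable from compound 2 to compound 3, and compound 3 is expected most likely to reach again only the limit of the assay.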

Compound 3, half-maximal cytotoxic concentration: > 1000 nM
Compound 3 gave a limit, no number; the forecaster's own chance of this, stated with the estimate: 80%; the middle value does not contradict the limit.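

In this assay compound 3 gives > 1000 nM, a limit of the assay and not a number. Among these compounds, compound 2 also stands at a limit, so no step from compound 2 to compound 3 can be read: the limit of > 1000 nM in this assay, at which 3 of the 3 values shown sit. The compounds shown leave open whether phenyl in place of cyclobutyl alters cytotoxicity, and at what concentration any of them would reach its half-maximal cytotoxic effect.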